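The compounds below may be only part of what the source reports. "The series", "measured", "known", "first", "only" and "open" are said of these compounds alone.

Measured compounds:
compound 1, `CCCCCOC1(c2ccc(Cl)cc2)SC=C(C)n2c1noc2=O`; in a functional assay on A2780/DX3 cells (Homo sapiens) for antiproliferative activity, read by MTT assay, with a stated time of 3 days (on this read-out lower numbers stand for stronger inhibition and higher numbers for weaker inhibition), compound 1 gives > 100000 nM, a limit of the assay.
compound 2, `COC1(c2ccc(Br)cc2)SC=C(C)n2c1noc2=O`; in this assay compound 2 gives > 100000 nM, again only a limit.
compound 3, `CC1=CSC(O)(c2cccc(Cl)c2)c2noc(=O)n21`; in this assay compound 3 gives > 100000 nM, also a limit.

Compound 2 stands where every measured compound stands, at the limit of > 100000 nM in this assay, at which 3 of the 3 values shown sit; no number separates the three, so no ordering among them can be drawn. Compound 4 is `CCCCCOC1(c2ccc(Br)cc2)SC=C(C)n2c1noc2=O`; it differs from compound 2 by butyl in place of hydrogen on a saturated chain carbon bound to an oxygen on a saturated carbon. Compound 1 carries the same pentyloxy group, with chlorine in place of bromine, and in this assay compound 1 gives > 100000 nM. On this basis no step beyond the scatter is expected, and the step from compound 2 to compound 4 is estimated at a step that the limit leaves unreadable from compound 2 to compound 4. For compound 4 in this assay the expected value is 150000 nM, range 50000 nM to 500000 nM, most likely reported only as a limit.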

Compound 4, half-maximal inhibitory concentration: > 100000 nM
Compound 4: no number, only a limit (the forecaster's own chance of this, stated with the estimate: 85%); the middle value lies beyond the limit too.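

The steps from compound 2 and compound 1 to compound 4 cannot be read in this assay, since all values are limits: the limit of > 100000 nM in this assay, at which 4 of the 4 values shown sit.

The compounds shown leave open whether methoxy to pentyloxy or bromo in place of chloro changes antiproliferative activity in any compound with a readable number.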